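Chloro in Place of Methoxy on the Phenyl Ring

The compounds below may be only part of what the source reports. "The series", "measured", "known", "first", "only" and "open" are said of these compounds alone.

In a functional assay on the whole organism (Abdomen, strain Swiss albino) with Mus musculus as the target, with stated times of 10 min and 5 min, at a dose of 30 mg/kg by the oral route (on this read-out lower numbers stand for a weaker effect and higher numbers for a stronger effect at the one dose given), compound 3 `COc1ccc(-c2nn(-c3ccccc3)cc2-c2cc(-c3ccccc3)on2)cc1` gives 31%, the low end of the three numbers shown. Compound 2 `Brc1ccc(-c2nn(-c3ccccc3)cc2-c2cc(-c3ccccc3)on2)cc1` gives 31.4%, within the scatter of compound 3, while compound 1 `Cc1ccc(N2C(=O)C3ON=C(c4cn(-c5ccccc5)nc4-c4ccc(Cl)cc4)C3C2=O)cc1` gives 42.8%, beyond it. Compound 4 `Clc1ccc(-c2nn(-c3ccccc3)cc2-c2cc(-c3ccccc3)on2)cc1` differs from compound 3 by chloro in place of methoxy on an aromatic carbon. Among the compounds with values here, one measured step bears on this: a number 0.4 percentage points lower from compound 2 to compound 3 (within the scatter), an exchange between a halogen and methoxy on an aromatic carbon that stayed within the scatter. The reverse exchange toward a different halogen is therefore expected to move the read-out by no more than the scatter, and no change at the digits printed from compound 3 to compound 4 (within the scatter) is the estimated step. Compound 4 is thus expected to give 31%, in the range from 22% to 40%.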

Compound 4, a percentage reported as activity, at one dose (the size of the read-out at that dose, not a potency): 49%
Estimate against measurement, compound 4: 18 percentage points below; measured number above the stated range.
By their numbers in this assay, from the lowest: compounds 3 and 2 (each within the scatter of the next); then compounds 1 and 4 (each within the scatter of the next).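

In this assay, the aromatic carbon para to a large group proves responsive after all, with a number 18 percentage points higher from compound 3 to compound 4 (beyond the scatter) and a number 17.6 percentage points higher from compound 2 to compound 4 (beyond the scatter), which the earlier pair, within the scatter of each other, gave no sign of. The response does not follow halogen as a class, since compound 2, with bromo, goes against any such reading. Nothing available accounts for why chloro differs from bromo and methoxy here. The compounds shown leave open how fluoro, an amine or a carboxylic acid on this carbon would read, and whether the unsubstituted phenyl would stand with compound 4 or with compound 3.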